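Swapping chloro for iodo on a dichloroacetamide aryl ring

A few compounds are considered here, and "the series" means these few. Any claim that something is new, unique, unknown or untested is made for them only; others in the source may bear on it.

Four close relatives share one core, a dichloroacetamide attached to a benzene ring. Compound 1 `Cc1ccc(NC(=O)C(Cl)Cl)cc1` carries a methyl group on that ring, and in a functional assay on Bel-7402 cells (Homo sapiens) for antiproliferative activity, read by MTT assay, with a stated time of 72 h (a lower number here means a stronger inhibitor, a higher number a weaker inhibitor), the result for compound 1 is "not determined" (no result reported). Compound 2 `O=C(Nc1ccc(F)cc1)C(Cl)Cl` carries fluoro, and in this assay the result for compound 2 is "not determined" (no result reported). Compound 3 `O=C(Nc1ccc(Cl)cc1)C(Cl)Cl` carries chloro, and in this assay compound 3 gives 49600 nM, which is the only numerical result in the set, so it cannot be ranked against anything else here.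

Compound 4 `O=C(Nc1ccc(I)cc1)C(Cl)Cl` differs from compound 3 in one place: iodo in place of chloro on an aromatic carbon. Within the data shown here, no measured pair shows what this exchange does, so the expectation rests on compound 3 alone. A shift no larger than the ordinary scatter is expected, perhaps leaning slightly toward stronger inhibition, and the expected step from compound 3 to compound 4 in this assay is a 1.4-fold lower number from compound 3 to compound 4 (0.15 log units; within the scatter). Compound 4 is therefore estimated at 35000 nM, with a likely range from 12000 nM to 100000 nM.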

Compound 4, half-maximal inhibitory concentration: 11900 nM
The estimate for compound 4 lay 2.9-fold (0.47 log units) above the measured number, outside the stated range (below it).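

Among these compounds, with only one number in the set, the earlier compounds could not show whether the group at this ring position matters at all. Placing iodo in place of chloro on this aromatic carbon gives a 4.2-fold lower number from compound 3 to compound 4 (0.62 log units; beyond the scatter) in this assay and so shows that this single-atom exchange can move the result toward stronger inhibition by more than ordinary assay variation. Nothing shown here gives a measured reason for this step.

With no numbers for compound 1 and compound 2, the methyl and fluoro groups cannot yet be placed alongside chloro and iodo. As far as these compounds go, it also remains open how an amine, a carboxylic acid or a longer chain at this position would compare with iodo, and whether any such group would take the activity further.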